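The source may hold more compounds than are shown below. What is called first, only, known or untested is meant among the compounds shown, and "the series" means these compounds.

Working notes on the series. Compound 1 `C[C@@H]1CN([C@@H](C)CO)C(=O)c2cccc(NC(=O)Nc3ccnc4ccccc34)c2O[C@H]1CN(C)S(=O)(=O)c1ccc2c(c1)OCCO2` gives 30300 nM in a physicochemical assay for solubility, read by HPLC, in phosphate buffer, measured as thermodynamic solubility, with a stated time of 24 h, at pH 7.4; a lower number here means a less soluble compound, a higher number a more soluble compound; compound 2 `C[C@@H]1CN([C@@H](C)CO)C(=O)c2cccc(NC(=O)Nc3cccc4cnccc34)c2O[C@H]1CN(C)S(=O)(=O)c1ccc2c(c1)OCCO2` gives 60500 nM, and compound 3 `C[C@@H]1CN([C@@H](C)CO)C(=O)c2cccc(NC(=O)Nc3cccc4ccncc34)c2O[C@H]1CN(C)S(=O)(=O)c1ccc2c(c1)OCCO2` gives 101000 nM, the highest of the three numbers. The steps of a 2.0-fold higher number from compound 1 to compound 2 (0.30 log units; within the scatter) and a 1.7-fold higher number from compound 2 to compound 3 (0.22 log units; within the scatter) stay within the scatter, while only a 3.3-fold higher number from compound 1 to compound 3 (0.52 log units; beyond the scatter) goes beyond it. Compound 4 `C[C@@H]1CN([C@@H](C)CO)C(=O)c2cccc(NC(=O)Nc3cccc4cccnc34)c2O[C@H]1CN(C)S(=O)(=O)c1ccc2c(c1)OCCO2` differs from compound 3 by quinolin-8-yl in place of isoquinolin-8-yl on an amide-type nitrogen. For the measured compounds named here, the measured steps that bear on this are the relocations of the ring nitrogen within the bicyclic group, all of which moved this assay little; no step for the quinolin-8-yl group itself exists. For compound 4 no step beyond the scatter is therefore expected, a 1.3-fold lower number from compound 3 to compound 4 (0.13 log units; within the scatter). Compound 4 is estimated at 75000 nM, with a range from 30000 nM to 200000 nM.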

Compound 4, solubility: 1800 nM
For compound 4 the middle estimate is 42-fold (1.62 log units) above the measured one, and the stated range ends above it.
By their numbers in this assay, from the lowest: compound 4; then compounds 1, 2 and 3 (each within the scatter of the next, the first and the last beyond it).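

At the amide-type nitrogen, where the ring nitrogen lies in the bicyclic group is not always a minor matter: in this assay, quinolin-8-yl gives a 56-fold lower number from compound 3 to compound 4 (1.75 log units; beyond the scatter), a 34-fold lower number from compound 2 to compound 4 (1.53 log units; beyond the scatter) and a 17-fold lower number from compound 1 to compound 4 (1.23 log units; beyond the scatter). The quinoline name alone does not go with the low number, as compound 1, with quinolin-4-yl, gives 30300 nM. No measurement shown accounts for the drop. Still open, on these data alone, is whether the drop is peculiar to quinolin-8-yl, or whether quinolin-5-yl, or quinolin-8-yl carrying an added amine or carboxylic acid, would give a similar number.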